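The compounds below may be only part of what the source reports. "The series", "measured", "known", "first", "only" and "open" are said of these compounds alone.

Measured so far in a functional assay on RAW264.7 cells (Mus musculus) for inhibition, read by ELISA, with a stated time of 24 h; a lower number here means that less compound is needed, a higher number that more compound is needed for the effect:
compound 1 `CC/C=C\C[C@H]1C(=O)C=C[C@H]1CC(=O)OCCCCC`: 25000 nM
compound 2 `CC/C=C\C[C@H]1C(=O)C=C[C@H]1CC(=O)OCCOCCOCCOC`: 35000 nM
compound 3 `CC/C=C\C[C@H]1C(=O)C=C[C@H]1CC(=O)OC(C)C`: 20000 nM

Compound 1 stands second highest of the three numbers; the nearest is a 1.3-fold lower number from compound 1 to compound 3 (0.10 log units; within the scatter), the furthest a 1.4-fold higher number from compound 1 to compound 2 (0.15 log units; within the scatter), both within the scatter. Compound 4 `CC/C=C\C[C@H]1C(=O)C=C[C@H]1CC(=O)OC(C)COC` differs from compound 1 by 1-(methoxymethyl)ethyl in place of pentyl on an oxygen next to a carbonyl group. For the measured compounds named here, two measured steps bear on this: the change of the ester alkyl group, a 1.3-fold lower number from compound 1 to compound 3 (0.10 log units; within the scatter), and the introduction of ether oxygens into the chain on the same oxygen, a 1.4-fold higher number from compound 1 to compound 2 (0.15 log units; within the scatter). Neither moved the number beyond the scatter. No step beyond the scatter is therefore expected from compound 1 to compound 4, the estimated step being no change at the digits printed from compound 1 to compound 4 (within the scatter). For compound 4 the value expected in this assay is 25000 nM, with a range of 12000 nM to 50000 nM.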

Compound 4, half-maximal effective concentration: 23000 nM
Estimate against measurement, compound 4: 1.1-fold (0.04 log units) above; measured number inside the range.
By their numbers in this assay, from the lowest: compounds 3, 4, 1 and 2 (each within the scatter of the next).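

On an oxygen next to a carbonyl group, 1-(methoxymethyl)ethyl in place of pentyl gives a 1.1-fold lower number from compound 1 to compound 4 (0.04 log units; within the scatter). Methoxy in place of hydrogen on a saturated chain carbon, two bonds along the chain from that oxygen, gives a 1.2-fold higher number from compound 3 to compound 4 (0.06 log units; within the scatter), so both routes to this group stay within the scatter. Nothing at hand accounts for these steps. On these data alone, whether a carboxylic acid or an amine at the end of the chain on this oxygen would give a step beyond the scatter remains open. As far as these compounds go, all four compounds share one core, so the effect of changes elsewhere also remains open.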